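Three Hydroxyphenyl Arms: One Ring Swap Shifts Cytotoxicity

A few compounds are considered here, and "the series" means these few. Any claim that something is new, unique, unknown or untested is made for them only; others in the source may bear on it.

Compound 3 `Oc1ccc(-c2cc(-c3ccccc3O)cc(-c3ccccc3O)n2)cc1` carries two 2-hydroxyphenyl groups and one 4-hydroxyphenyl group on the shared core. In a functional assay on DU-145 cells (Homo sapiens) for cytotoxicity, read by CCK-8 assay, with a stated time of 4 days (on this read-out higher numbers stand for weaker inhibition and lower numbers for stronger inhibition), compound 3 gives 360 nM, the lowest number among the three measured compounds. Compound 2 `Oc1ccc(-c2cc(-c3ccc(O)cc3)nc(-c3ccc(O)cc3)c2)cc1`, which bears three 4-hydroxyphenyl groups, gives 3160 nM in this assay, and compound 1 `Oc1ccc(-c2cc(-c3ccccc3O)cc(-c3cccc(O)c3)n2)cc1` gives 5370 nM. Within the data shown here, the only single-change step among the measured compounds is a 15-fold lower number from compound 1 to compound 3 (1.17 log units; beyond the scatter), and it shows that the position of the hydroxyl on one arm can move the number well beyond the scatter.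

Compound 4 `Oc1ccc(-c2cc(-c3ccccc3O)cc(-c3ccc(O)cc3)n2)cc1` remains unmeasured. It differs from compound 3 by 4-hydroxyphenyl in place of 2-hydroxyphenyl on an aromatic carbon. Among the measured compounds shown here, no measured step covers this exact exchange, but compound 4 sits structurally between compound 3 and compound 2, whose values bracket the likely outcome. Compound 4 is therefore expected to give about 1200 nM in this assay, within a range of 400 nM to 3500 nM. This estimate corresponds to a 3.3-fold higher number from compound 3 to compound 4 (0.52 log units; beyond the scatter), a rise in the number expected to exceed the scatter.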

Compound 4, half-maximal inhibitory concentration: 980 nM
For compound 4 the middle estimate is 1.2-fold (0.09 log units) above the measured one; the measured number falls inside the stated range.
By their numbers in this assay, from the lowest: compound 3; then compound 4; then compounds 2 and 1 (each within the scatter of the next).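

With compound 4 included, all three hydroxyphenyl arms can be read at the same place, next to the ring nitrogen, while the rest of the molecule stays fixed. In this assay the 4-hydroxyphenyl arm gives a 2.7-fold higher number from compound 3 to compound 4 (0.43 log units; beyond the scatter) but still a 5.5-fold lower number from compound 1 to compound 4 (0.74 log units; beyond the scatter), so at this place the 2-hydroxyphenyl arm gives the lowest number, the 3-hydroxyphenyl arm the highest and the 4-hydroxyphenyl arm lies in between. A change on a different arm of the shared core also moves the number, with a 3.2-fold lower number from compound 2 to compound 4 (0.51 log units; beyond the scatter), so this place is not the only one that responds. Nothing shown here explains these differences. The compounds shown leave open whether the hydroxyl itself is needed at this place, since no arm carrying a methoxy group or an amine appears among them. They also leave open how an arm without any substituent, a plain phenyl, would compare.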